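The source may hold more compounds than are shown below. What is called first, only, known or untested is meant among the compounds shown, and "the series" means these compounds.

In an ADME assay on HEK293 cells (Homo sapiens) for inhibition, read by MTT assay, with a stated time of 3 days (on this read-out lower numbers stand for stronger inhibition and higher numbers for weaker inhibition), three compounds with a shared core have been measured. Compound 1 `COc1ccc(/C=C\c2cc(OC)c(OC)c(OC)c2)cc1OCc1ccccc1` gives 15000 nM, compound 2 `COc1cccc(/C=C/CCCOc2cc(/C=C\c3cc(OC)c(OC)c(OC)c3)ccc2OC)c1` gives 39000 nM, and compound 3 `COCOc1ccccc1/C=C/CCCOc1cc(/C=C\c2cc(OC)c(OC)c(OC)c2)ccc1OC` gives 106000 nM, the highest number of the three. Compound 4 `COCOc1ccc(/C=C/CCCOc2cc(/C=C\c3cc(OC)c(OC)c(OC)c3)ccc2OC)cc1` has the same atoms as compound 3, joined differently: 4-(methoxymethoxy)phenyl stands in place of 2-(methoxymethoxy)phenyl on a double-bonded chain carbon bound to a double-bonded chain carbon (4-(methoxymethoxy)phenyl in place of 2-(methoxymethoxy)phenyl on a double-bonded chain carbon bound to a double-bonded chain carbon). Going by the values given here, two measured steps bear on this change. The closer one changes the group at that same place, a 2.7-fold higher number from compound 2 to compound 3 (0.43 log units; beyond the scatter), and it is modest. The other, a 2.6-fold higher number from compound 1 to compound 2 (0.41 log units; beyond the scatter), is of similar size and changes the group on the chain. Among the compounds with values here, no measured compound carries 4-(methoxymethoxy)phenyl, so the direction rests on little. Within the data shown here, compound 3 has the highest number so far, and the closer step was modest, so a modest move towards lower numbers is expected, and the expected step in this assay is a 2.1-fold lower number from compound 3 to compound 4 (0.33 log units; beyond the scatter). Compound 4 is estimated at 50000 nM, with an expected range from 18000 nM to 130000 nM.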

Compound 4, half-maximal inhibitory concentration: 25000 nM
Beside the measured number, compound 4's estimate is 2.0-fold (0.30 log units) above it; the measured number falls inside the stated range.
By their numbers in this assay, from the lowest: compounds 1, 4 and 2 (each within the scatter of the next, the first and the last beyond it); then compound 3.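

In this assay, 4-(methoxymethoxy)phenyl in place of 2-(methoxymethoxy)phenyl gives a 4.2-fold lower number from compound 3 to compound 4 (0.63 log units; beyond the scatter) on an otherwise unchanged structure, so with the same atoms, the way this group is joined is enough to move the number beyond the scatter. Set against 3-methoxyphenyl at that same place, 4-(methoxymethoxy)phenyl gives a 1.6-fold lower number from compound 2 to compound 4 (0.19 log units; within the scatter) and cannot be told apart from it here, which leaves 2-(methoxymethoxy)phenyl as the only one of these three groups that stands apart. No evidence is available that bears on this difference.

Still open, going by these compounds, is what 3-(methoxymethoxy)phenyl, 4-hydroxyphenyl or 4-aminophenyl would give at this place. Also open, on these data alone, is whether the change from 2-(methoxymethoxy)phenyl to 4-(methoxymethoxy)phenyl would give a step of similar size on a shorter or longer chain.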